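A methoxymethyl extension on compound 2

A few compounds are considered here, and "the series" means these few. Any claim that something is new, unique, unknown or untested is made for them only; others in the source may bear on it.

- Compound 1 `CC/C=C\C[C@H]1C(=O)C=C[C@H]1CC(=O)OCCOCCO`: 36000 nM
- Compound 2 `CC/C=C\C[C@H]1C(=O)C=C[C@H]1CC(=O)OCCOC`: 27000 nM
- Compound 3 `CC/C=C\C[C@H]1C(=O)C=C[C@H]1CC(=O)OCCOCCOC`: not yet measured

In a functional assay on RAW264.7 cells (Mus musculus) for inhibition, read by ELISA, with a stated time of 24 h (a higher number here means that more compound is needed for the effect, a lower number that less compound is needed), compound 2 gives 27000 nM, and this stands level with compound 1 once the usual scatter of repeated measurements is allowed for. Compound 3 keeps the shared core and differs only at the end of the chain: methoxymethyl in place of hydrogen on a saturated chain carbon bound to an oxygen on a saturated carbon. Read one bond further out, this is methoxy to 2-methoxyethoxy. Among the measured compounds shown here, only one measured step bears on it, a 1.3-fold lower number from compound 1 to compound 2 (0.12 log units; within the scatter). That step swapped hydroxymethyl for hydrogen at the same kind of carbon and stayed within the scatter. A single step is thin evidence, so the range stays wide. The expected change is a 1.1-fold higher number from compound 2 to compound 3 (0.05 log units; within the scatter), which means no expected shift beyond the scatter. Compound 3 is estimated at 30000 nM, with an expected range of 14000 nM to 65000 nM.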

Compound 3, half-maximal effective concentration: 33000 nM
The estimate for compound 3 lay 1.1-fold (0.04 log units) below the measured number, and the stated range covers the measured number.
By their numbers in this assay, from the lowest: compounds 2, 3 and 1 (each within the scatter of the next).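

In this assay, the earlier step took a group away at this saturated chain carbon bound to an oxygen on a saturated carbon, whereas this change adds methoxymethyl there, and the result stays within the scatter (a 1.2-fold higher number from compound 2 to compound 3 (0.09 log units; within the scatter)). A second change at the chain end, methyl in place of hydrogen on an oxygen on a saturated carbon, also stays within the scatter (a 1.1-fold lower number from compound 1 to compound 3 (0.04 log units; within the scatter)), so in this small set neither lengthening the chain end nor capping its hydroxyl moves the number measurably. No measurement here explains why these changes leave the number in place.

As far as these compounds go, whether an amine or a carboxylic acid at this chain end would shift the number beyond the scatter remains open. The same holds for a much longer chain or a phenyl ring placed there.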